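The source may hold more compounds than are shown below. What is called first, only, known or untested is meant among the compounds shown, and "the series" means these compounds.

Measured so far in a functional assay on CHO cells for inhibition of Orexin/Hypocretin receptor type 1 (Homo sapiens), read by FLIPR and calcium flux (on this read-out higher numbers stand for weaker inhibition and lower numbers for stronger inhibition), each value being a limit of this assay rather than a number:

Compound 1 `CCN(CC)C(=O)CN(c1ccc(C)cc1)S(=O)(=O)c1ccc(OC(F)(F)F)cc1` gives > 10000 nM.
Compound 2 `CCN(CC)C(=O)CN(c1ccc(C)cc1)S(=O)(=O)c1cccc(C)c1` gives > 10000 nM.
Compound 3 `CCN(CC)C(=O)CN(c1ccc(C)cc1)S(=O)(=O)c1ccc(C#N)cc1` gives > 10000 nM.

Compound 3 therefore stands where the other two stand: at the limit, with no number attached to it (the limit of > 10000 nM in this assay, at which 3 of the 3 values shown sit). The two changes that lead into it on the same aromatic ring, a step that the two limits leave unreadable from compound 1 to compound 3 and a step that the two limits leave unreadable from compound 2 to compound 3, cannot be sized, since both ends of each step sit at the limit.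

The next compound, compound 4 `CCN(CC)C(=O)CN(c1ccc(C)cc1)S(=O)(=O)c1ccc(Br)cc1`, differs from compound 3 in one place: bromo in place of cyano on an aromatic carbon. The measured steps that bear on it are the two just named, both changes of the group on this aromatic ring, and neither shows a readable size. Nothing among the measured compounds points to a step in either direction beyond the scatter, and no cause for the three limits is given by the data.

The expectation for compound 4 is thus a step that the limit leaves unreadable from compound 3 to compound 4 in this assay, most likely again a limit. Compound 4 is estimated at 15000 nM, with a range from 5000 nM to 50000 nM.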

Compound 4, half-maximal inhibitory concentration: > 10000 nM
Compound 4 gave a limit, no number; the forecaster's own chance of this, stated with the estimate: 85%; the middle value does not contradict the limit.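

Compound 4 adds no readable step: its comparisons with compound 1, compound 2 and compound 3 in this assay each join two limits rather than two numbers, and all four compounds sit together: the limit of > 10000 nM in this assay, at which 4 of the 4 values shown sit. The compounds shown leave open whether these groups differ in inhibition at all, and which change to the shared core would give a measurable value.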